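Swapping the chalcogen on a fused quinoline core: methoxy next

A few compounds are considered here, and "the series" means these few. Any claim that something is new, unique, unknown or untested is made for them only; others in the source may bear on it.

Measured compounds:
- compound 1, `C[Se]c1c(SCC#CCO)cnc2ccccc12`: 2.1 ug/mL
- compound 2, `CSc1c(SCC#CCO)cnc2ccccc12`: 13.9 ug/mL

In a functional assay on CCRF-CEM cells (Homo sapiens) for cytotoxicity, read by sulforhodamine B assay, with a stated time of 72 h (a higher number here means a weaker inhibitor, a lower number a stronger inhibitor), compound 2 holds the highest number of the two, with compound 1 at the lower end. Compound 3, `COc1c(SCC#CCO)cnc2ccccc12`, arises from compound 2 by methoxy in place of methylsulfanyl on an aromatic carbon. For the measured compounds named here, the only step that bears on it is the change of this same group from selenium to sulfur, where a 6.6-fold higher number from compound 1 to compound 2 (0.82 log units; beyond the scatter) was seen. A further exchange at the same spot is expected to give a modest rise at most, so compound 3 is estimated at 20 ug/mL (range 7 ug/mL to 60 ug/mL), a step of a 1.4-fold higher number from compound 2 to compound 3 (0.16 log units; within the scatter).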

Compound 3, concentration for 50% inhibition: 22 ug/mL
For compound 3 the middle estimate is 1.1-fold (0.04 log units) below the measured one; the range from low to high includes it.
By their numbers in this assay, from the lowest: compound 1; then compounds 2 and 3 (each within the scatter of the next).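

Changing methylsulfanyl to methoxy made no clear difference in this assay (a 1.6-fold higher number from compound 2 to compound 3 (0.20 log units; within the scatter)), so sulfur and oxygen cannot be told apart at this aromatic carbon. Selenium does stand apart from oxygen here (a 10-fold higher number from compound 1 to compound 3 (1.02 log units; beyond the scatter)), and with the earlier step this sets compound 1 apart from both other compounds. No measurement shown explains this difference.

From the compounds shown here alone, it remains open whether an amine or a longer chain such as ethoxy at this carbon would behave like compound 1 or like compound 2 and compound 3. Going by these compounds, it is also open whether selenium keeps its lead when the other side chain changes.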